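Replacing the Nitrophenyl Amide with a Thiazolyl Amide

This account rests on a few compounds, and the source may have more. Where it says the series, first, only, none or still open, it means among the compounds named here.

Measured so far:
compound 1 `O=C(NCc1ccccc1)c1c(O)c2cccnc2n(-c2ccccc2)c1=O`: 11.3%
compound 2 `O=C(Nc1ccc(Cl)cc1)c1c(O)c2cccnc2n(-c2ccccc2)c1=O`: 2.5%
compound 3 `O=C(Nc1ccc([N+](=O)[O-])cc1)c1c(O)c2cccnc2n(-c2ccccc2)c1=O`: -25.8%

All three share one core and differ only in the group on the amide-type nitrogen. In a functional assay on the whole organism for inhibition, with Rattus norvegicus as the target, read by cytopathic effect and paw edema, at a dose of 100 mg/kg by the oral route (a higher number here means more inhibition at the dose given (going by the name of the read-out), a lower number less inhibition), compound 3 gives -25.8%, the lowest of the three numbers. Its nearest neighbour is compound 2, and the step of a number 28.3 percentage points lower from compound 2 to compound 3 (beyond the scatter) lies beyond the scatter; the gap to compound 1, a number 37.1 percentage points lower from compound 1 to compound 3 (beyond the scatter), is larger still. Compound 1 and compound 2 sit within the scatter of each other, a number 8.8 percentage points lower from compound 1 to compound 2 (within the scatter).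

Compound 4 `O=C(Nc1nccs1)c1c(O)c2cccnc2n(-c2ccccc2)c1=O` has not been measured in this assay. It differs from compound 3 in one place: 1,3-thiazol-2-yl in place of 4-nitrophenyl on an amide-type nitrogen.

For the measured compounds named here, the steps that bear on this change are the two that end at compound 3, both downward and both beyond the scatter. Since the group that is removed from compound 3 is the 4-nitrophenyl that marked those steps, and the 1,3-thiazol-2-yl that enters resembles none of the groups already tried, compound 4 is expected to move back toward the other two, though the size is uncertain. The step of a number 28.8 percentage points higher from compound 3 to compound 4 (beyond the scatter) is the estimated change. For compound 4 the estimate in this assay is 3%, with a range from -20% to 28%.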

Compound 4, a percentage reported as inhibition, in the whole organism at one dose (the size of the read-out at that dose, not a potency): 2.5%
For compound 4 the middle estimate is 0.5 percentage points above the measured one, within the range that was stated.
By their numbers in this assay, from the lowest: compound 3; then compounds 2, 4 and 1 (each within the scatter of the next).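

Putting 1,3-thiazol-2-yl in place of 4-nitrophenyl on the amide-type nitrogen gives a number 28.3 percentage points higher from compound 3 to compound 4 (beyond the scatter) in this assay, so the low reading of compound 3 does not extend to every aromatic ring at this position. The thiazolyl group cannot be told apart from the other two groups, with no change at the digits printed from compound 2 to compound 4 (within the scatter) and a number 8.8 percentage points lower from compound 1 to compound 4 (within the scatter), which leaves 4-nitrophenyl as the only group among these four that stands apart from the rest. Nothing measured here explains why that one group separates from the others.

Going by these compounds, it remains open whether any group on this nitrogen can lift the inhibition clearly beyond the scatter around compound 1, which gives 11.3%, for instance a longer chain ending in an amine or a carboxylic acid. On these data alone, it is also open whether the low reading of compound 3 belongs to the nitro group itself, a question that a 4-aminophenyl or 4-carboxyphenyl group in its place on the same nitrogen would help to answer.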